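The compounds below may be only part of what the source reports. "The series", "measured", "known", "first", "only" and "open" are said of these compounds alone.

Working notes on the series. Compound 1 `COc1ccc(OCC2=NCCO2)cc1` gives 10% in a toxicity assay on the whole organism with Rattus norvegicus as the target, at a dose of 200 mg/kg by the oral route (on this read-out lower numbers stand for a weaker effect and higher numbers for a stronger effect at the one dose given), and compound 2 `Cc1ccccc1OCC1=NCCO1` gives 20% in this assay, a reading that sits within the scatter of compound 1, so the two stand level and no trend is visible. Compound 3 `Fc1ccc(OCC2=NCCO2)cc1` remains to be measured in this assay. It differs from compound 1 by fluoro in place of methoxy on an aromatic carbon. Among the measured compounds shown here, no step between measured compounds sizes such a change. The expected step of a number 5 percentage points higher from compound 1 to compound 3 (within the scatter) is none beyond the scatter, since the two readings in hand spread little. Compound 3 is estimated at 15% in this assay, with a range from 0% to 35%.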

Compound 3, a percentage reported as activity, at one dose (the size of the read-out at that dose, not a potency): 25%
Estimate against measurement, compound 3: 10 percentage points below; measured number inside the range.
By their numbers in this assay, from the lowest: compounds 1, 2 and 3 (each within the scatter of the next, the first and the last beyond it).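

Among the compounds shown here, at this aromatic carbon, para to a group of 7 heavy atoms, fluoro in place of methoxy gives a number 15 percentage points higher from compound 1 to compound 3 (beyond the scatter) in this assay and is the first sized step. The reading at this position therefore responds to a change of group, though only modestly. Nothing at hand bears on what lies behind this step.

Going by these compounds, whether chloro, an amine or a carboxylic acid on the same carbon would shift the reading further remains open. So does whether fluoro gives a step of similar size on other carbons of the aromatic ring.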